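Oxazole-carboxamide piperazines: aryl swap on the ring nitrogen

The compounds below may be only part of what the source reports. "The series", "measured", "known", "first", "only" and "open" are said of these compounds alone.

Measured so far:
Compound 1 `COc1cc(OC)cc(N2CCN(C(=O)c3oc(C)nc3-c3cccc(F)c3)CC2)c1` gives 28.2 nM in a functional assay on HL-60 cells (Homo sapiens) for inhibition, read by MTT assay, with a stated time of 72 h; a lower number here means a stronger inhibitor, a higher number a weaker inhibitor.
Compound 2 `Cc1nc(-c2ccccc2)c(C(=O)N2CCN(c3c(C)cccc3C)CC2)o1` gives 146 nM in this assay.
Compound 3 `CCc1nc(-c2ccccc2F)c(C(=O)N2CCN(c3cccc(Cl)c3)CC2)o1` gives 139 nM in this assay.

Compound 2 carries the highest number of the three. Its nearest neighbour is compound 3, whose number is lower by an amount that stays within the scatter, so the two cannot be put in order. Among the measured compounds shown here, compound 1 stands apart from compound 2, with a lower number beyond the scatter, and no single-point step connects either of these pairs.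

Compound 4 `Cc1nc(-c2ccccc2)c(C(=O)N2CCN(c3cccc(C)c3C)CC2)o1` is the next to be measured in this assay. It keeps every atom of compound 2 and changes only the arrangement of the aryl group on the amine nitrogen in the ring:

2,3-dimethylphenyl in place of 2,6-dimethylphenyl on an amine nitrogen in a ring

Nothing in the measured set isolates this kind of rearrangement on the piperazine aryl group, so no direction can be read off. The step from compound 2 to compound 4 is expected to be a 1.3-fold lower number from compound 2 to compound 4 (0.12 log units; within the scatter), most likely not beyond the scatter, with any movement more probable toward a lower number than toward a higher one. For compound 4 the expected value in this assay is 110 nM, with a range from 40 nM to 300 nM.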

Compound 4, half-maximal inhibitory concentration: 35 nM
Estimate against measurement, compound 4: 3.1-fold (0.50 log units) above; measured number outside the range, below it.
By their numbers in this assay, from the lowest: compounds 1 and 4 (each within the scatter of the next); then compounds 3 and 2 (each within the scatter of the next).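

Among the compounds shown here, replacing 2,6-dimethylphenyl with 2,3-dimethylphenyl on the amine nitrogen in a ring gives a 4.2-fold lower number from compound 2 to compound 4 (0.62 log units; beyond the scatter) in this assay and is the first single-place step. For the compounds shown here, the two groups have the same heavy atoms, the same aromatic ring and the same donor and acceptor counts, so the arrangement of the two methyl groups alone is enough to move the number at this position beyond the scatter, something the earlier compounds, which differ in more than one place, could not show. No measurement bears on why the number moves, and the result is recorded here only as an observed difference.

This single pair, with its methyl and phenyl groups on the shared core, leaves open whether the same rearrangement would give a similar step on the cores of compound 1 or compound 3. Also open, as far as these compounds go, is how this position responds to other groups on the aryl ring, such as a nitrile, a trifluoromethyl group or a carboxylic acid, and to other arrangements of the two methyl groups.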